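This account rests on a few compounds, and the source may have more. Where it says the series, first, only, none or still open, it means among the compounds named here.

In a functional assay on GBM2 cells (Homo sapiens) for antiproliferative activity, read by WST assay, with a stated time of 72 h (a higher number here means a weaker inhibitor, a lower number a stronger inhibitor), compound 1 (`O=C(Nc1cc2ncncc2cc1OCc1ccc(Cl)cc1)Nc1cccc2ccccc12`) gives 4500 nM and compound 2 (`O=C(Nc1ccccc1F)Nc1cc2ncncc2cc1OCc1ccccc1`) gives 4500 nM on the same reading, so compound 1 stands level with compound 2 and the numbers do not separate them. Compound 3 (`O=C(Nc1cc2ncncc2cc1OCc1cccc(F)c1)Nc1cccc2ccccc12`) has not been measured yet. It keeps the core of compound 1 and carries 3-fluorophenyl in place of 4-chlorophenyl on a saturated chain carbon bound to an oxygen on an aromatic ring. Going by the values given here, no two measured compounds differ in just one place, so the data give no direct guide to this change. In this assay no step beyond the scatter is expected, in either direction. This expectation rests only on compound 1 at 4500 nM and compound 2 at 4500 nM as the values at hand. For compound 3 the estimated value is 4000 nM with an expected range from 1500 nM to 10000 nM around it.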

Compound 3, half-maximal inhibitory concentration: 1400 nM
Estimate against measurement, compound 3: 2.9-fold (0.46 log units) above; the whole stated range lies above it.
By their numbers in this assay, from the lowest: compound 3; then compounds 1 and 2 (each within the scatter of the next).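

The group on the saturated chain carbon bound to an oxygen on an aromatic ring can change the result: in this assay, replacing 4-chlorophenyl with 3-fluorophenyl gives a 3.2-fold lower number from compound 1 to compound 3 (0.51 log units; beyond the scatter), a modest step but one beyond the scatter. The two groups have the same number of heavy atoms and differ only in which halogen they carry and where its number places it on the ring, yet even this small swap moves the reading. Nothing measured here explains why the number falls.

Halogen and placement changed together, so the step cannot be assigned to either one alone; 3-chlorophenyl and 4-fluorophenyl would be needed to pull them apart. Also open, as far as these compounds go, is how the reading would respond to a different group here, such as a pyridine ring or a longer chain.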